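A Chloro Substituent Carried Across Two Related Cores

The source may report more compounds than this note shows. Statements on the series, on what has been measured and on what is new or still open speak of the compounds shown alone.

compound 1, `COc1ccc(OC)c(-c2cc(-c3ccccc3)nn2-c2ccc(S(=O)(=O)NC(C)=O)cc2)c1`: 49800 nM
compound 2, `COc1ccc(OC)c(-c2cc(-c3ccc(Cl)cc3)nn2-c2ccc(S(=O)(=O)NC(C)=O)cc2)c1`: 52600 nM
compound 3, `NS(=O)(=O)c1ccc(-n2nc(-c3ccccc3)cc2-c2cc(O)ccc2O)cc1`: 100000 nM

In a functional assay on cells (Cancer cell lines, Homo sapiens) for cytotoxicity, read by sulforhodamine B assay, with a stated time of 48 h (on this read-out higher numbers stand for weaker inhibition of growth and lower numbers for stronger inhibition of growth), compound 1 gives 49800 nM and compound 2 gives 52600 nM. The change between them is chloro in place of hydrogen on an aromatic carbon, and the step it made was a 1.1-fold higher number from compound 1 to compound 2 (0.02 log units; within the scatter). Compound 3 gives 100000 nM in this assay; the difference between its core and that of compound 1 is not broken down here, and its value and that of compound 2 lie within the usual scatter of each other.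

Compound 4, `NS(=O)(=O)c1ccc(-n2nc(-c3ccc(Cl)cc3)cc2-c2cc(O)ccc2O)cc1`, is not yet measured. It differs from compound 3 by chloro in place of hydrogen on an aromatic carbon, the same change as before, at a place described in the same words. The expected step is no change at the digits printed from compound 3 to compound 4 (within the scatter), resting on the earlier 1.1-fold higher number from compound 1 to compound 2 (0.02 log units; within the scatter), which stayed within the scatter. Compound 4 is therefore estimated at 100000 nM, with a range from 50000 nM to 200000 nM.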

Compound 4, concentration for total growth inhibition: 39100 nM
Compound 4: the middle estimate sits 2.6-fold (0.41 log units) above what was measured; the whole stated range lies above it.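

In this assay chloro in place of hydrogen gave a 2.6-fold lower number from compound 3 to compound 4 (0.41 log units; beyond the scatter) and so went with stronger inhibition of growth on this core, while the same change on the core of compound 1 stayed within the scatter. The change therefore did not carry the same step from one core to the other: the same change on two cores in this assay, a 1.1-fold higher number (0.02 log units; within the scatter) from compound 1 to compound 2 and a 2.6-fold lower number (0.41 log units; beyond the scatter) from compound 3 to compound 4, 2.7-fold (0.43 log units) apart, beyond the scatter of two such steps. This shows that the step on one core was no reliable guide to the step on the other, but with a single pair on each core it does not show which feature of the cores sets the two steps apart.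

The compounds shown leave open whether another group at this place, such as bromo or an amine, would also give different steps on the two cores. They also leave open whether the gap would persist on a further core.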